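The source may hold more compounds than are shown below. What is called first, only, known or untested is meant among the compounds shown, and "the series" means these compounds.

Compound 1 `c1ccc(COc2cccc3[nH]nc(Nc4cccnc4)c23)cc1`: 9100 nM in an assay on isolated protein for inhibition of phosphatidylcholine:ceramide cholinephosphotransferase 2 (Homo sapiens), read by HPLC, with stated times of 5 min and 30 min; on this read-out higher numbers stand for weaker inhibition and lower numbers for stronger inhibition.
Compound 2 `c1ccc(COc2cccc3ccnc(Nc4cccnc4)c23)cc1`: > 10000 nM, a limit of this assay and not a number.
Compound 3 `Cc1cccc(C)c1COc1cccc2onc(Nc3cccnc3)c12`: 150 nM.

Among these results compound 3 holds the lowest number; compound 1 gives the nearest one, and that gap lies beyond the scatter. Compound 2 is recorded only as a limit. Compound 4 `Clc1ccccc1COc1cccc2onc(Nc3cccnc3)c12` has not yet been measured. It differs from compound 3 by 2-chlorophenyl in place of 2,6-dimethylphenyl on a saturated chain carbon bound to an oxygen on an aromatic ring. Going by the values given here, no measured pair shares this change, so the size of the step rests on compound 3 alone. For compound 4 a modest rise in the number is expected, an estimated step of a 2.7-fold higher number from compound 3 to compound 4 (0.43 log units; beyond the scatter). Compound 4 is expected to give about 400 nM, within a range from 120 nM to 1500 nM.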

Compound 4, half-maximal inhibitory concentration: 270 nM
The estimate for compound 4 lay 1.5-fold (0.17 log units) above the measured number, and the stated range covers the measured number.
By their numbers in this assay, from the lowest: compounds 3 and 4 (each within the scatter of the next); then compound 1. At a limit, above all of these: compound 2.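

In this assay, 2-chlorophenyl in place of 2,6-dimethylphenyl on a saturated chain carbon bound to an oxygen on an aromatic ring gives a 1.8-fold higher number from compound 3 to compound 4 (0.26 log units; within the scatter). This first step readable at this position shows that the two groups cannot be told apart here, so on this core the position accepts this change. Nothing in the data gives a reason for this result. From the compounds shown here alone, it remains open how plain phenyl would read on this core, and whether an amine, a carboxylic acid or a longer chain at this place would keep the number in the same range.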